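Ring stereocentre inversion in a cyclic peroxide acid pair

The compounds below may be only part of what the source reports. "The series", "measured", "known", "first", "only" and "open" are said of these compounds alone.

Working notes on the series. Compound 1 `COC(=O)[C@H](C)[C@H]1CC[C@@](C)(CCC2=C(C)CCCC2(C)C)OO1` and compound 2 `C=C1CCCC(C)(C)C1CC[C@@]1(C)CC[C@H]([C@@H](C)C(=O)O)OO1` share a core. Among the measured compounds shown here, in a functional assay on HCT-116 cells (Homo sapiens) for inhibition (a higher number here means a weaker inhibitor of growth, a lower number a stronger inhibitor of growth), compound 2 gives 5190 nM, the only number so far. Compound 1 reaches only a limit in this assay, > 25000 nM, which is not a number. That limit is where compound 1 sits (the limit of > 25000 nM in this assay, at which 1 of the 2 values shown sits).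

Compound 3 `C=C1CCCC(C)(C)C1CC[C@]1(C)CC[C@@H]([C@@H](C)C(=O)O)OO1` is not yet measured. Against compound 2 it differs as the two compounds have the same atoms and bonds; at least one stereo element is drawn with a configuration in one of them and without one in the other: 2 of 4 stereo elements differ; a stereocentre at a saturated ring carbon is drawn S in compound 2 and R in compound 3; a stereocentre at a saturated ring carbon is drawn R in compound 2 and S in compound 3. For the measured compounds named here, no measured pair of this kind exists here, so the direction is open; a change in either sense beyond the scatter is possible. The step is expected to be a 1.7-fold higher number from compound 2 to compound 3 (0.24 log units; within the scatter). Compound 3 is estimated at 9000 nM, within 2000 nM to 40000 nM.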

Compound 3, concentration for 50% growth inhibition: > 10000 nM
Compound 3: no number, only a limit; the forecaster's own chance of this, stated with the estimate: 25%; at least 1.1-fold (0.04 log units) between middle value and limit.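

The ring stereocentre inversion now has its first reading in this assay: an at least 1.9-fold higher number from compound 2 to compound 3 (0.28 log units; that floor lies within the scatter). Compound 3 gives no number, only a limit: the limit of > 10000 nM in this assay, at which 1 of the 3 values shown sits.

As far as these compounds go, the true size of the step therefore stays unknown, and its floor alone does not separate the two compounds, although the inverted acid shows no measurable growth inhibition up to that limit. Open, from the compounds shown here alone, is the effect of inverting either ring stereocentre alone, and whether an amide in place of the carboxylic acid would keep the reading of compound 2.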